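Swapping the aryl piece on a piperazine amine for pyridyl

The compounds below may be only part of what the source reports. "The series", "measured", "known", "first", "only" and "open" are said of these compounds alone.

Three close relatives of one shared core have been tested for binding to the adenosine A3 receptor. In an assay on CHO cells for displacement of a labelled ligand from adenosine receptor A3 (Homo sapiens), read by scintillation counting, with a stated time of 120 min, tested at 10 uM (on this read-out lower numbers stand for less inhibition and higher numbers for more inhibition at the one concentration tested (going by the name of the read-out)), compound 1 `CC(C)N1CCN(Cc2csc(N)c2C(=O)c2ccc(Cl)cc2)CC1` gives 0%. In this assay compound 2 `Nc1scc(CN2CCN(c3cccc(Cl)c3Cl)CC2)c1C(=O)c1ccc(Cl)cc1` gives 0%, level with compound 1, and in this assay compound 3 `Nc1scc(CN2CCN(c3ccc(Cl)c(C(F)(F)F)c3)CC2)c1C(=O)c1ccc(Cl)cc1` gives 3%, a value within the usual scatter of the other two. All three therefore show essentially no displacement of the labelled ligand at the single concentration tested.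

Compound 4 `Nc1scc(CN2CCN(c3ccncc3)CC2)c1C(=O)c1ccc(Cl)cc1` has not yet been measured. It differs from compound 2 in one place: pyridin-4-yl in place of 2,3-dichlorophenyl on an amine nitrogen in a ring. Going by the values given here, the steps that bear on this change are the ones that swapped the group on the same ring nitrogen: no change at the digits printed from compound 1 to compound 2 (within the scatter), a number 3 percentage points higher from compound 2 to compound 3 (within the scatter) and a number 3 percentage points higher from compound 1 to compound 3 (within the scatter). None of them moved the read-out beyond the scatter, so a further swap at that position is expected to leave it flat, with a number 2 percentage points higher from compound 2 to compound 4 (within the scatter). Compound 4 is thus estimated to give 2% in this assay, within a range of 0% to 12%.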

Compound 4, a percentage reported as inhibition, at one concentration (the size of the read-out at that concentration, not a potency): 2%
For compound 4 middle estimate and measured number coincide at the digits printed; the range from low to high includes it.
By their numbers in this assay, from the lowest: compounds 1, 2, 4 and 3 (each within the scatter of the next).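

Pyridin-4-yl puts a ring nitrogen and a hydrogen-bond acceptor on the piperazine amine where 2,3-dichlorophenyl had neither, yet in this assay this swap gives a number 2 percentage points higher from compound 2 to compound 4 (within the scatter). The comparisons with the other two groups agree, with a number 1 percentage points lower from compound 3 to compound 4 (within the scatter) and a number 2 percentage points higher from compound 1 to compound 4 (within the scatter), so an aromatic ring with a hetero atom now joins isopropyl and the two chlorinated phenyl rings in leaving the read-out flat at this position. No supporting data are available to explain this flatness.

Since all four compounds sit near the bottom of the read-out, these results cannot rank the groups against one another. Still open, as far as these compounds go, is whether a group of another kind on this nitrogen, such as an acetyl group or a chain ending in a carboxylic acid, or a change elsewhere on the shared core, would lift the read-out beyond the scatter.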